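Inverting One Stereocentre of Compound 3

The source may report more compounds than this note shows. Statements on the series, on what has been measured and on what is new or still open speak of the compounds shown alone.

In a functional assay on MCF7 cells (Homo sapiens) for antiproliferative activity, read by luminescence and CellTiter-Glo, with a stated time of 48 h (on this read-out lower numbers stand for stronger inhibition and higher numbers for weaker inhibition), compound 1 (`COc1ccc(/C=C/[C@@H]2CC=CC(=O)O2)cc1`) gives 88700 nM as its reading. Compound 2 (`O=C1C=CC[C@@H](/C=C/c2ccc([N+](=O)[O-])cc2)O1`) stands at > 100000 nM which is a limit of the assay. Compound 3 (`O=C1C=CC[C@H](/C=C/c2ccc(F)cc2)O1`) gives 76200 nM and this lies within the usual scatter of the reading for compound 1.

Compound 4 (`O=C1C=CC[C@@H](/C=C/c2ccc(F)cc2)O1`) has not yet been measured. Its relation to compound 3 is simple: the two compounds have the same atoms and bonds and differ only in configuration as drawn: 1 of 2 stereo elements differ; a stereocentre at a saturated ring carbon is drawn R in compound 3 and S in compound 4 and nothing else changes. For the measured compounds named here, the only measured step, an at least 1.1-fold higher number from compound 1 to compound 2 (0.05 log units; that floor lies within the scatter), exchanges a ring substituent and does not touch configuration, so it gives no direct measure of an inversion. Its floor also stays within the scatter. With compound 3 at 76200 nM as the closest reference, no shift beyond the scatter is expected in this assay for this change. The expected change is a 1.1-fold lower number from compound 3 to compound 4 (0.04 log units; within the scatter) and it is estimated to remain within the scatter. Compound 4 is estimated at 70000 nM with an expected range from 30000 nM to 100000 nM on this measure.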

Compound 4, half-maximal inhibitory concentration: > 100000 nM
Compound 4 was reported as a limit (the forecaster's own chance of this, stated with the estimate: 20%); at least 1.4-fold (0.15 log units) between middle value and limit.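

In this assay, the inversion gives a direct reading for this stereocentre at a saturated ring carbon, an at least 1.3-fold higher number from compound 3 to compound 4 (0.11 log units; that floor lies within the scatter), so a shift beyond the scatter is neither shown nor excluded, and the step carries no other change: the fact that compounds 3 and 4 differ only in the configuration as drawn. The exchange of groups on the aromatic carbon gives an at least 1.1-fold higher number from compound 1 to compound 4 (0.05 log units; that floor lies within the scatter), so this change also shows no shift beyond the scatter. The step from compound 2 to compound 4 cannot be read, as both values are limits: the limit of > 100000 nM in this assay, at which 2 of the 4 values shown sit.

The compounds shown leave open how far the true value of compound 4 lies from its limit, and so how large the inversion really is. They also leave open whether an amine or a carboxylic acid on that aromatic carbon would give a reading clear of the limit, and whether inversion would then matter.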